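This account rests on a few compounds, and the source may have more. Where it says the series, first, only, none or still open, it means among the compounds named here.

Compound 1 `CN(C(=O)NC(=O)c1ccc(F)c(F)c1)c1nc(C(F)(F)F)c(C(=O)N/N=C/c2ccc(C(F)(F)F)cc2)s1`: 3.85 ug/mL
Compound 2 `CN(C(=O)NC(=O)c1cccc(C(F)(F)F)c1)c1nc(C(F)(F)F)c(C(=O)N/N=C/c2ccc(C(F)(F)F)cc2)s1`: 4.22 ug/mL
Compound 3 `CN(C(=O)NC(=O)c1cccc(C(F)(F)F)c1)c1nc(C(F)(F)F)c(C(=O)N/N=C/c2ccccc2C(F)(F)F)s1`: 7.29 ug/mL

In a functional assay on BCG823 cells (Homo sapiens) for inhibition, read by MTT assay, with a stated time of 72 h (on this read-out higher numbers stand for weaker inhibition and lower numbers for stronger inhibition), compound 3 gives the highest of these three numbers, though its gaps to compound 2 and to compound 1 both lie within the scatter. Compound 4 `CN(C(=O)NC(=O)c1ccc(F)c(F)c1)c1nc(C(F)(F)F)c(C(=O)N/N=C/c2ccccc2C(F)(F)F)s1` differs from compound 3 by 3,4-difluorophenyl in place of 3-(trifluoromethyl)phenyl on a carbonyl carbon. The same exchange, run the other way, is seen in a 1.1-fold higher number from compound 1 to compound 2 (0.04 log units; within the scatter), a step within the scatter; the other step, a 1.7-fold higher number from compound 2 to compound 3 (0.24 log units; within the scatter), concerns a different position and bears on it less. A step of about that size is therefore expected, leaning toward a slightly lower number, or none beyond the scatter. Compound 4 is estimated at 6.6 ug/mL, with a range from 3.5 ug/mL to 12.5 ug/mL. The expected step is a 1.1-fold lower number from compound 3 to compound 4 (0.04 log units; within the scatter).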

Compound 4, half-maximal inhibitory concentration: 3.66 ug/mL
For compound 4 the middle estimate is 1.8-fold (0.26 log units) above the measured one; measured number inside the range.
By their numbers in this assay, from the lowest: compounds 4, 1, 2 and 3 (each within the scatter of the next).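

On the carbonyl carbon, 3,4-difluorophenyl in place of 3-(trifluoromethyl)phenyl gives a 2.0-fold lower number from compound 3 to compound 4 (0.30 log units; within the scatter), and on the carbon with a double bond to nitrogen, 2-(trifluoromethyl)phenyl in place of 4-(trifluoromethyl)phenyl gives a 1.1-fold lower number from compound 1 to compound 4 (0.02 log units; within the scatter). The first exchange can now be read on a second core, and the two readings agree: the same change on two cores in this assay, a 1.1-fold higher number (0.04 log units; within the scatter) from compound 1 to compound 2 and a 2.0-fold higher number (0.30 log units; within the scatter) from compound 4 to compound 3, 1.8-fold (0.26 log units) apart, within the scatter of two such steps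
The second exchange can also be read twice, again with agreement: the same change on two cores in this assay, a 1.7-fold higher number (0.24 log units; within the scatter) from compound 2 to compound 3 and a 1.1-fold lower number (0.02 log units; within the scatter) from compound 1 to compound 4, 1.8-fold (0.26 log units) apart, within the scatter of two such steps

All four compounds carry fluorinated phenyl groups at both places. On these data alone, what an amine or a carboxylic acid on those rings would do in this assay stays open.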